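Working notes: an ethoxy to methoxy step in one series

The source may report more compounds than this note shows. Statements on the series, on what has been measured and on what is new or still open speak of the compounds shown alone.

compound 1 `O=C(NCCCCc1ccccc1)c1cccc(C2SCC(=O)N2c2ccccc2)c1`: 89%
compound 2 `Cc1cccc(N2C(=O)CSC2c2cccc(C(=O)NCCCCc3ccccc3)c2)c1`: 93%
compound 3 `CCOc1ccccc1N1C(=O)C(C)SC1c1cccc(C(=O)NCCCCc2ccccc2)c1`: 92%

In a functional assay on MG-63 cells (Homo sapiens) for inhibition, read by CCK-8 assay, with a stated time of 72 h, tested at 1 uM (on this read-out lower numbers stand for less inhibition and higher numbers for more inhibition at the one concentration tested (going by the name of the read-out)), compound 3 gives 92%, with its gap to compound 2 and its gap to compound 1 both within the scatter, so the three measured numbers sit together. Within the data shown here, the only single-place step measured is a number 4 percentage points higher from compound 1 to compound 2 (within the scatter), which concerns a different part of the structure and stays within the scatter. Compound 4 `COc1ccccc1N1C(=O)C(C)SC1c1cccc(C(=O)NCCCCc2ccccc2)c1` differs from compound 3 by hydrogen in place of methyl on a saturated chain carbon bound to an oxygen on an aromatic ring. Among the measured compounds shown here, no measured step touches the ethoxy group, so nothing here points either way; the three close numbers show only that the inhibition in this assay has stayed level across the small edits measured so far. The expected step in this assay is therefore a number 1 percentage points lower from compound 3 to compound 4 (within the scatter), none beyond the scatter. Compound 4 is estimated at 91%, with a range from 83% to 97%.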

Compound 4, a percentage reported as inhibition, at one concentration (the size of the read-out at that concentration, not a potency): 94%
For compound 4 the middle estimate is 3 percentage points below the measured one, within the range that was stated.
By their numbers in this assay, from the lowest: compounds 1, 3, 2 and 4 (each within the scatter of the next).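

Among these compounds, on the 2-ethoxyphenyl group, ethoxy to methoxy is the first step read at this position. In this assay it reads a number 2 percentage points higher from compound 3 to compound 4 (within the scatter), so cutting the chain from ethyl to methyl leaves the inhibition level at the one concentration tested. Nothing further is on hand to interpret this step.

The compounds shown leave open whether a longer chain such as propoxy, or an amine or a carboxylic acid in place of the methoxy group, would hold that level. They also leave open whether the step would read the same at a lower concentration.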